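The source may report more compounds than this note shows. Statements on the series, on what has been measured and on what is new or still open speak of the compounds shown alone.

Measured compounds:
- compound 1 `CCCn1c(=O)[nH]c(=O)c2[nH]c(-c3cnn(Cc4ccccc4)c3)nc21` — "not determined" (no result reported) in an assay on CHO cells for displacement of a labelled ligand from adenosine receptor A3 (Homo sapiens); a higher number here means a weaker inhibitor, a lower number a stronger inhibitor
- compound 2 `CCCn1c(=O)[nH]c2nc(-c3cnn(Cc4ccccc4)c3)[nH]c2c1=O` — 120 nM

Among the measured compounds shown here, compound 2 is the only compound of this pair with a number in this assay, so it stands alone as the reference point: in this assay compound 2 gives 120 nM. Compound 1 carries the same benzylpyrazole side group on a differently arranged core, and for it no inhibition constant was reported, so no comparison between the two can be drawn.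

Compound 3 `CCCn1c(=O)[nH]c2nc(-c3cnn(Cc4cccc(F)c4)c3)[nH]c2c1=O` is the next compound to be measured. It differs from compound 2 in one place only: fluoro in place of hydrogen on an aromatic carbon. For the measured compounds named here, since no step between two measured compounds is available here, there is nothing in these data that tells how a fluoro in place of hydrogen on the benzyl ring shifts the inhibition constant in this assay.

With no shown step to lean on, the expectation for compound 3 is a step from compound 2 that stays within the usual scatter: a 1.2-fold lower number from compound 2 to compound 3 (0.08 log units; within the scatter). Compound 3 is therefore expected to give about 100 nM in this assay, with a plausible range from 35 nM to 300 nM.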

Compound 3, inhibition constant: 160 nM
For compound 3 the middle estimate is 1.6-fold (0.20 log units) below the measured one; measured number inside the range.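

Among the compounds shown here, this is the first step that can be read on the benzyl ring: in this assay, going from benzyl to 3-fluorobenzyl gives a 1.3-fold higher number from compound 2 to compound 3 (0.12 log units; within the scatter) and so leaves the two compounds indistinguishable. The aromatic carbon meta to a large group therefore takes a single fluoro in place of hydrogen with a result that cannot be told apart from repeat measurement, which is all that this one pair can show for this position and says nothing about any other carbon of the ring. Nothing in the data speaks to why the step is this small.

From the compounds shown here alone, it remains open whether a larger group on the same aromatic carbon, such as chloro, methoxy or trifluoromethyl, would give a step beyond the scatter, and whether fluoro on another carbon of that ring would behave as it does here. Equally open, going by these compounds, is what an amine or a carboxylic acid on the benzyl ring would do, or how a longer chain in place of the propyl group on the shared core would read in this assay against the values of compound 2 and compound 3.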